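Ethoxy to propoxy on the shared core

A few compounds are considered here, and "the series" means these few. Any claim that something is new, unique, unknown or untested is made for them only; others in the source may bear on it.

In a functional assay for inhibition, with Homo sapiens as the target (on this read-out higher numbers stand for weaker inhibition and lower numbers for stronger inhibition), compound 1 (`COc1ccc(-c2nc(-c3ccc4c(c3)CCC(=O)N4)cs2)cc1`) gives 9000 nM and compound 2 (`CCOc1cc(-c2nc(-c3ccc4c(c3)CCC(=O)N4)cs2)ccc1OC`) gives 90 nM as the lower of the two numbers. Compound 3 (`CCCOc1cc(-c2nc(-c3ccc4c(c3)CCC(=O)N4)cs2)ccc1OC`) differs from compound 2 by methyl in place of hydrogen on a saturated chain carbon, two bonds along the chain from an oxygen on an aromatic ring in the form of methyl in place of hydrogen on a saturated chain carbon, two bonds along the chain from an oxygen on an aromatic ring, which reads ethoxy to propoxy. Among the compounds with values here, the only measured step bearing on this is a 100-fold lower number from compound 1 to compound 2 (2.00 log units; beyond the scatter) for ethoxy in place of hydrogen on an aromatic carbon. That step is large, but it compares no chain lengths. The expected step is a 1.3-fold lower number from compound 2 to compound 3 (0.11 log units; within the scatter) and no change beyond the scatter is expected in this assay in either direction. For compound 3 the estimated value is 70 nM with an expected range of 20 nM to 300 nM on this read-out.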

Compound 3, half-maximal inhibitory concentration: 90 nM
For compound 3 the middle estimate is 1.3-fold (0.11 log units) below the measured one; low and high end bracket the measured number.
By their numbers in this assay, from the lowest: compounds 2 and 3 (each within the scatter of the next); then compound 1.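

In this assay, lengthening the chain on this oxygen from ethoxy to propoxy leaves the number unchanged (no change at the digits printed from compound 2 to compound 3 (within the scatter)). The comparison with compound 1 also shows a large step (a 100-fold lower number from compound 1 to compound 3 (2.00 log units; beyond the scatter)), so the gain over compound 1 holds for both chain lengths, and these two chains are not separated in this assay. Nothing available gives a reason for this result. From the compounds shown here alone, whether a butoxy or longer chain stays at this level remains open, as does the effect of an amine at the end of the chain.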